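Bromine on the pyridine core and alpha3/beta4 agonism

A few compounds are considered here, and "the series" means these few. Any claim that something is new, unique, unknown or untested is made for them only; others in the source may bear on it.

Measured compounds:
Compound 1, `COc1cncc(N2CC[C@H]3CN[C@H]3C2)c1`: 180 nM
Compound 2, `COc1cc(N2CC[C@H]3CN[C@H]3C2)cnc1Br`: 8 nM
Compound 3, `N#Cc1cncc(N2C[C@@H]3CCNC[C@@H]32)c1`: 2560 nM

In a functional assay on HEK293 cells for agonist activity at Neuronal acetylcholine receptor; alpha3/beta4 (Homo sapiens), read by FLIPR (a lower number here means that less compound is needed, a higher number that more compound is needed for the effect), compound 1 gives 180 nM, while compound 2 gives 8 nM. The two differ in one place, (bromo in place of hydrogen on an aromatic carbon), and the step of a 23-fold lower number from compound 1 to compound 2 (1.35 log units; beyond the scatter). Compound 3 stands highest of the three measured values, above compound 1 and far above compound 2; how its core differs from that of compound 1 is not broken down here.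

Compound 4, `N#Cc1cc(N2C[C@@H]3CCNC[C@@H]32)cnc1Br`, has not been measured in this assay. It arises from compound 3 by bromo in place of hydrogen on an aromatic carbon, the same kind of change as from compound 1 to compound 2, found in these two pairs. The surroundings are not identical: in compound 2 the bromo sits ortho to a methoxy group, in compound 4 ortho to a cyano group, on a different core. A somewhat smaller step in the same direction is expected, estimated as a 10-fold lower number from compound 3 to compound 4 (1.01 log units; beyond the scatter), resting on the step from compound 1 to compound 2 and on the value of compound 3. Compound 4 is therefore expected at 250 nM, with a range from 60 nM to 1000 nM.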

Compound 4, half-maximal effective concentration: 794 nM
Beside the measured number, compound 4's estimate is 3.2-fold (0.50 log units) below it; measured number inside the range.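

In this assay, bromo in place of hydrogen on an aromatic carbon lowers the number on the second core as well, with a 3.2-fold lower number from compound 3 to compound 4 (0.51 log units; beyond the scatter), so the direction of the change carries over from one core to the other. The size of the step does not carry over, and the gap between the two steps is larger than repeated measurement would account for: the same change on two cores in this assay, a 23-fold lower number (1.35 log units; beyond the scatter) from compound 1 to compound 2 and a 3.2-fold lower number (0.51 log units; beyond the scatter) from compound 3 to compound 4, 7.0-fold (0.84 log units) apart, beyond the scatter of two such steps. These two pairs do not show what sets the size of the step, for they differ both in the core and in the group that shares the ring with the bromo, a methoxy group in compound 2 and a cyano group in compound 4.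

Going by these compounds, it remains open whether the step would keep its size with the methoxy group on the core of compound 3, or with the cyano group on the core of compound 1. Also open, on these data alone, is how chloro, an amine or a longer chain on the same aromatic carbon would compare with bromo on either core.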